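From 1H-imidazol-4-yl to bromo on the shared core

The compounds below may be only part of what the source reports. "The series", "measured", "known", "first", "only" and "open" are said of these compounds alone.

Of the compounds shown here, three sharing one core have numbers so far in a functional assay, read by Griess assay, with a stated time of 2.5 h (a lower number here means a stronger inhibitor, a higher number a weaker inhibitor), and they sit close together. Compound 1 (`COc1cc(OC)c(OC)cc1/C=C/C(=O)c1ccc(-c2c[nH]cn2)cc1`) gives 1.97 ug/mL there. Compound 2 (`COc1cc(OC)c(OC)cc1/C=C/C(=O)c1ccc(Cl)c([N+](=O)[O-])c1`) gives 1.99 ug/mL and compound 3 (`COc1cc(OC)c(OC)cc1/C=C/C(=O)c1cccc(C(F)(F)F)c1`) gives 2.09 ug/mL so all three lie within the scatter of one another, and compound 1 stands level with both.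

Compound 4 (`COc1cc(OC)c(OC)cc1/C=C/C(=O)c1ccc(Br)cc1`) has not yet been measured. Its difference from compound 1 (bromo in place of 1H-imidazol-4-yl on an aromatic carbon) is bromo in place of 1H-imidazol-4-yl on an aromatic carbon of a six-membered aromatic ring of carbon only, para to a large group.

No measured pair in the series differs in one place only, so the size of this swap is not shown directly. Compound 1 (1.97 ug/mL) and compound 3 (2.09 ug/mL) carry different groups on that ring yet remain within the scatter of each other. On that basis no step beyond the scatter is expected in this assay and no firm direction can be called. The expected change is a 1.2-fold higher number from compound 1 to compound 4 (0.07 log units; within the scatter) and it is estimated to stay within the scatter. The estimated value for compound 4 is 2.3 ug/mL (expected range 1.1 ug/mL to 4.8 ug/mL).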

Compound 4, half-maximal inhibitory concentration: 2.22 ug/mL
Estimate against measurement, compound 4: 1.0-fold (0.02 log units) above; the measured number falls inside the stated range.
By their numbers in this assay, from the lowest: compounds 1, 2, 3 and 4 (each within the scatter of the next).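

Among the compounds shown here, the first pair that differs in one place gives a direct reading for this swap in this assay: bromo in place of 1H-imidazol-4-yl on an aromatic carbon para to a large group is a 1.1-fold higher number from compound 1 to compound 4 (0.05 log units; within the scatter). At this position, a five-membered aromatic ring with 2 hetero atoms, 1 hydrogen-bond donor and 1 hydrogen-bond acceptor can therefore give way to a single bromine atom with no donor or acceptor, and the number stays within the scatter, so this pair shows no need for that ring in this assay. No measurement in hand explains why the two numbers stay level.

Whether other kinds of group behave the same way at this position stays open, since an amine, a carboxylic acid and a longer alkyl chain are not among the compounds shown. Compound 2 and compound 3 each differ from compound 1 and from compound 4 in more than one place, so the single-place effects of their chloro, nitro and trifluoromethyl groups cannot be read from this set.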